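Benzoxaborole amides: acetyl for chloro on the distal ring

The source may hold more compounds than are shown below. What is called first, only, known or untested is meant among the compounds shown, and "the series" means these compounds.

The series is followed in a functional assay on HCT-116 cells (Homo sapiens) for antiproliferative activity, read by MTT assay, with a stated time of 72 h; a higher number here means a weaker inhibitor, a lower number a stronger inhibitor. Compound 1 `CC(C)(C)OC(=O)Nc1ccc(NC(=O)CCc2cccc3c2B(O)OC3)cc1` gives 24000 nM there. Compound 2 `O=C(CCc1cccc2c1B(O)OC2)Nc1cccc(-c2cccc(Cl)c2)c1` gives 350 nM in this assay, the lowest of the two numbers recorded so far; its nearest neighbour is compound 1, whose number is higher by a margin well beyond the scatter. Compound 3 `CC(=O)c1cccc(-c2cccc(NC(=O)CCc3cccc4c3B(O)OC4)c2)c1` has not yet been measured in this assay.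

The change from compound 2 to compound 3 is acetyl in place of chloro on an aromatic carbon; the group enters on an aromatic carbon of a six-membered aromatic ring of carbon only, on the outer ring of the 3-chlorophenyl unit, which becomes 3-acetylphenyl.

Among the measured compounds shown here, no step between measured compounds is available for comparison, so the expectation for this assay rests on compound 2 alone. A modest rise in the number is expected, of a size that may stay within the scatter or slightly exceed it, since compound 2 gives 350 nM. The estimated step from compound 2 to compound 3 is a 2.0-fold higher number from compound 2 to compound 3 (0.30 log units; within the scatter). Compound 3 is expected to give about 700 nM, in a range from 200 nM to 2500 nM.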

Compound 3, half-maximal inhibitory concentration: 86 nM
Estimate against measurement, compound 3: 8.1-fold (0.91 log units) above, outside the stated range (below it).
By their numbers in this assay, from the lowest: compound 3; then compound 2; then compound 1.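

In this assay, replacing 3-chlorophenyl with 3-acetylphenyl gives a 4.1-fold lower number from compound 2 to compound 3 (0.61 log units; beyond the scatter), a change beyond the scatter, so the number falls rather than rises on this exchange. Among the compounds shown here, until now, this position on the outer ring was known only through the single chloro example in compound 2, which said nothing of how far the group there could change; it now appears open to acetyl, with 3 heavy atoms against 1 and with 1 hydrogen-bond acceptor where chloro has 0. No measured evidence here explains why the acetyl compound gives the lower number.

On these data alone, with a single pair, it remains open whether the lower number follows the carbonyl itself or would also appear with other groups in the same place, such as an amine, a carboxylic acid, a nitrile or a longer acyl chain like propanoyl. For the compounds shown here, it is also open whether acetyl would give a similar step at another carbon of the outer ring, and whether any such step would carry over to a core other than the one shared by compound 2 and compound 3.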